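The source may hold more compounds than are shown below. What is called first, only, known or untested is meant among the compounds shown, and "the series" means these compounds.

Compound 2 `Cn1ccc2c(Oc3ccc(NC(=O)c4cc5cccnc5n(-c5ccccc5)c4=O)cc3F)ccnc21` gives 510 nM in a functional assay on HT-29 cells (Homo sapiens) for antiproliferative activity, read by MTT assay, with a stated time of 72 h (on this read-out higher numbers stand for weaker inhibition and lower numbers for stronger inhibition), and compound 1 `Cn1ccc2c(Oc3ccc(NC(=O)c4cc5cccnc5n(-c5ccccc5)c4=O)cc3)ccnc21` gives 620 nM; the two numbers lie within the scatter of each other, the step being a 1.2-fold lower number from compound 1 to compound 2 (0.08 log units; within the scatter). Compound 3 `Cn1ccc2c(Oc3ccc(NC(=O)c4cc5cccnc5n(-c5ccc(Br)cc5F)c4=O)cc3F)ccnc21` differs from compound 2 by 4-bromo-2-fluorophenyl in place of phenyl on an aromatic nitrogen. Among the compounds with values here, no measured step changes the group on that aromatic nitrogen, so the only step in hand, from compound 1 to compound 2, does not speak to this change. Compound 3 is therefore expected to show a 1.1-fold lower number from compound 2 to compound 3 (0.05 log units; within the scatter), no move beyond the scatter. The estimated value of compound 3 is 450 nM, ranging from 150 nM to 1300 nM.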

Compound 3, half-maximal inhibitory concentration: 3290 nM
Compound 3: the middle estimate sits 7.3-fold (0.86 log units) below what was measured; measured number outside the range, above it.
By their numbers in this assay, from the lowest: compounds 2 and 1 (each within the scatter of the next); then compound 3.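

On the aromatic nitrogen, the group matters in this assay: 4-bromo-2-fluorophenyl in place of phenyl produces a 6.5-fold higher number from compound 2 to compound 3 (0.81 log units; beyond the scatter) and so weaker inhibition, the first move here beyond the scatter. The earlier fluoro in place of hydrogen, by contrast, gave only a 1.2-fold lower number from compound 1 to compound 2 (0.08 log units; within the scatter). Nothing available explains why this change weakens inhibition.

Still open, on these data alone, is whether the bromine or the fluorine carries the step, since the two enter together. Also open, as far as these compounds go, is how this position would read with a smaller alkyl group such as methyl, or with a phenyl bearing an amine.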